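A few compounds are considered here, and "the series" means these few. Any claim that something is new, unique, unknown or untested is made for them only; others in the source may bear on it.

Of the compounds shown here, two share a common core and have been measured in a functional assay for antagonist activity at transient receptor potential cation channel subfamily V member 1 (Homo sapiens), read by FLIPR; on this read-out higher numbers stand for weaker inhibition and lower numbers for stronger inhibition. Compound 1 `Cc1cccnc1-c1ccc(C(=O)Nc2ccc(C(F)(F)F)cc2)cc1` gives 65 nM in this assay. Compound 2 `CC(C)(C)c1ccc(NC(=O)c2ccc(-c3ccccn3)cc2)cc1` gives 11 nM in this assay, which is the lowest of the two numbers; the gap between compound 1 and compound 2 lies beyond the usual scatter.

Compound 3 `CCS(=O)(=O)Nc1cccnc1-c1ccc(C(=O)Nc2ccc(C(C)(C)C)cc2)cc1` has not yet been measured in this assay. It differs from compound 2 in one place: (ethylsulfonyl)amino in place of hydrogen on an aromatic carbon. No comparable change is represented among the measured compounds, so nothing in the present numbers shows which way such an addition moves the read-out. On that basis a step of only modest size is expected, from a 1.8-fold higher number from compound 2 to compound 3 (0.26 log units; within the scatter), with no confident direction. Compound 3 is therefore estimated at 20 nM in this assay, with a range from 4 nM to 100 nM.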

Compound 3, half-maximal inhibitory concentration: 49 nM
Compound 3: the middle estimate sits 2.5-fold (0.39 log units) below what was measured, within the range that was stated.
By their numbers in this assay, from the lowest: compound 2; then compounds 3 and 1 (each within the scatter of the next).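

In this assay, (ethylsulfonyl)amino in place of hydrogen, on an aromatic carbon ortho to a large group and two atoms from the ring nitrogen, brings a 4.5-fold higher number from compound 2 to compound 3 (0.65 log units; beyond the scatter) in a single change. The position therefore responds to this substitution, yet the inhibition is not lost, since compound 3 still reads 49 nM in this assay. Nothing available accounts for the direction or size of this step.

The compounds shown leave open which part of the entering group carries the step, as a plain amine or a methylsulfonylamino group at the same place would be needed to separate the nitrogen, the sulfonyl and the ethyl chain. They also leave open whether a longer chain on the sulfonyl or a carboxylic acid at this position would read differently.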